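A few compounds are considered here, and "the series" means these few. Any claim that something is new, unique, unknown or untested is made for them only; others in the source may bear on it.

The compounds measured so far:

Compound 1, `CCN(CC)S(=O)(=O)c1ccc(S(=O)(=O)N2CCC[C@@H](C(=O)N[C@H]3CC[C@H](OC)CC3)C2)cc1`, gives in a functional assay on MIA PaCa-2 cells (Homo sapiens) for inhibition, read by MTT assay, with a stated time of 3 days (a higher number here means a weaker inhibitor, a lower number a stronger inhibitor), the limit value > 10000 nM, which is a limit of the assay and not a number.
Compound 2, `CCN(CC)S(=O)(=O)c1ccc(S(=O)(=O)N2CCC[C@@H](C(=O)N[C@H]3CC[C@@H](OC)CC3)C2)cc1`, gives in this assay the limit value > 10000 nM, again a limit.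
Compound 3, `CCN(CC)S(=O)(=O)c1ccc(S(=O)(=O)N2CCC[C@@H](C(=O)N3CCC(F)(F)CC3)C2)cc1`, gives in this assay the limit value > 10000 nM, also a limit.

Compound 3 therefore stands at the same limit as the other two; none of the three is separated from another, because of the limit of > 10000 nM in this assay, at which 3 of the 3 values shown sit. The step between compound 1 and compound 2 rests only on configuration as drawn, (the fact that compounds 1 and 2 differ only in the configuration as drawn), and is unreadable: a step that the two limits leave unreadable from compound 1 to compound 2. The exchanges of the amide substituent are likewise unreadable, a step that the two limits leave unreadable from compound 1 to compound 3 and a step that the two limits leave unreadable from compound 2 to compound 3.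

Compound 4, `CCN(CC)S(=O)(=O)c1ccc(S(=O)(=O)N2CCC[C@@H](C(=O)N[C@@H]3CCOC3)C2)cc1`, differs from compound 3 by (oxolan-3-yl)amino in place of 4,4-difluoropiperidin-1-yl on a carbonyl carbon. Going by the values given here, no measured step bears a readable size on this change; the only information is that every exchange at the carbonyl carbon so far left the compound at the limit. Compound 4 is therefore expected to stay at or near that limit, with the step that the limit leaves unreadable from compound 3 to compound 4 estimated as no change beyond the scatter. The estimate for compound 4 in this assay is 15000 nM, ranging from 4000 nM to 60000 nM.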

Compound 4, half-maximal inhibitory concentration: > 10000 nM
Compound 4 ended at the assay's limit; the forecaster's own chance of this, stated with the estimate: 85%; the middle value does not contradict the limit.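

No step from compound 4 to compound 1, compound 2 or compound 3 can be read, because all four compounds stand at the same limit, which is not a number: the limit of > 10000 nM in this assay, at which 4 of the 4 values shown sit.

The compounds shown leave open whether any change to the amide substituent gives a measurable value in this assay.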